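Aryl swap on the shared core: outlook for compound 3

The source may report more compounds than this note shows. Statements on the series, on what has been measured and on what is new or still open speak of the compounds shown alone.

The series is read in an assay on Sf9 cells for inhibition of protein deacetylase HDAC6 (Homo sapiens), read by fluorescence, with a stated time of 40 min, tested at 100 nM; on this read-out lower numbers stand for less inhibition and higher numbers for more inhibition at the one concentration tested (going by the name of the read-out). Compound 1 `O=C(NO)c1ccc(NCc2nc(-c3cccnc3)nn2-c2ccccc2)cc1` gives 57.7%. Among the compounds with values here, compound 2 `CC(C)c1ccc(-c2nc(CNc3ccc(C(=O)NO)cc3)n(-c3ccccc3)n2)cc1` gives 27.6%, the lowest of the two numbers so far; its only neighbour is compound 1, reached through the single measured step, a number 30.1 percentage points lower from compound 1 to compound 2 (beyond the scatter). Compound 3 `O=C(NO)c1ccc(NCc2nc(-c3ccccc3Cl)nn2-c2ccccc2)cc1` differs from compound 2 by 2-chlorophenyl in place of 4-isopropylphenyl on an aromatic carbon. Within the data shown here, no measured step covers this exact exchange. Among the measured compounds shown here, the one step that touches the same aromatic carbon, a number 30.1 percentage points lower from compound 1 to compound 2 (beyond the scatter), shows that the group on that position can shift inhibition by a large amount, and it is the entry of 4-isopropylphenyl that coincides with the low number of compound 2. With 4-isopropylphenyl leaving and a group of fewer heavy atoms entering, compound 3 is expected to regain part of that loss, estimated as a number 17.4 percentage points higher from compound 2 to compound 3 (beyond the scatter). The expected value for compound 3 is 45%, within a range of 20% to 70%.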

Compound 3, a percentage reported as inhibition, at one concentration (the size of the read-out at that concentration, not a potency): 75%
Estimate against measurement, compound 3: 30 percentage points below, outside the stated range (above it).
By their numbers in this assay, from the lowest: compound 2; then compound 1; then compound 3.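

The aromatic carbon between two ring nitrogen atoms can carry inhibition upward as well as downward: 2-chlorophenyl gives a number 47.4 percentage points higher from compound 2 to compound 3 (beyond the scatter) and a number 17.3 percentage points higher from compound 1 to compound 3 (beyond the scatter), which places compound 3 highest of the three. A six-membered aromatic ring of carbon only stands at both ends of this order, in compound 2 and compound 3, so that ring alone does not set the number; what its substituent contributes remains a matter of the two groups compared here. No measurement at hand explains the size of either step.

Still open, from the compounds shown here alone, is whether the gain follows the chlorine itself or its place on the ring, a question that phenyl without a substituent, 4-chlorophenyl and 2-methylphenyl on this carbon would address. Also open, going by these compounds, is how an amine such as morpholine, or a longer alkyl chain, would read at this position.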